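Testing a New Aryl Group for Metabolic Stability

The source may report more compounds than this note shows. Statements on the series, on what has been measured and on what is new or still open speak of the compounds shown alone.

Compound 1 `O=S(=O)(c1cc(Cl)cc(Cl)c1)c1cnc2cc(F)ccc2c1-c1ccccc1F` was examined in an ADME assay on microsomes from liver (Homo sapiens) for metabolic stability, tested at 2.5 uM (a lower number here means slower removal, a higher number faster removal of the compound), where compound 1 gives 0.93 mL/min. Two relatives share its core: compound 2 `O=S(=O)(c1ccc(F)c(F)c1)c1cnc2cc(F)ccc2c1-c1ccccc1F` gives 0.79 mL/min and compound 3 `O=S(=O)(c1ccc(F)c(Cl)c1)c1cnc2cc(F)ccc2c1-c1ccccc1F` gives 1.07 mL/min. Compound 1 stands within the scatter of both, with a 1.2-fold lower number from compound 1 to compound 2 (0.07 log units; within the scatter) and a 1.2-fold higher number from compound 1 to compound 3 (0.06 log units; within the scatter). The step of a 1.4-fold higher number from compound 2 to compound 3 (0.13 log units; within the scatter) is likewise within the scatter. Compound 4 `O=S(=O)(c1cc(Cl)cc(Cl)c1)c1cnc2cc(F)ccc2c1-c1ccc(Cl)cc1` differs from compound 1 in one place: 4-chlorophenyl in place of 2-fluorophenyl on an aromatic carbon. Among the compounds with values here, the 4-chlorophenyl enters on an aromatic carbon opposite the ring nitrogen, a place no measured step touches; every measured step concerns the group on the sulfonyl sulfur, and none left the scatter. No step beyond the scatter is therefore expected. Compound 4 is estimated at 1 mL/min, with a range from 0.5 mL/min to 2 mL/min. That estimate means an expected step of a 1.1-fold higher number from compound 1 to compound 4 (0.03 log units; within the scatter).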

Compound 4, intrinsic clearance in a liver preparation (reported as CLH), per the amount of preparation that the assay uses: 0.13 mL/min
Estimate against measurement, compound 4: 7.7-fold (0.89 log units) above, outside the stated range (below it).
By their numbers in this assay, from the lowest: compound 4; then compounds 2, 1 and 3 (each within the scatter of the next).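

Changing the aryl group at this position has a clear effect in this assay, with a 7.2-fold lower number from compound 1 to compound 4 (0.85 log units; beyond the scatter) when 4-chlorophenyl replaces 2-fluorophenyl. The earlier changes, all on the sulfonyl sulfur, stayed within the scatter, so this is the first place shown where one change moves the number beyond it. No measurement at hand explains this step.

The swap changes both the halogen and its place on the ring, so the two remain unseparated. On these data alone, whether 4-fluorophenyl, 2-chlorophenyl or a phenyl carrying an amine or a carboxylic acid would give a similar result stays open.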